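Methoxy to methanesulfonamido on an indane imidazole scaffold

A few compounds are considered here, and "the series" means these few. Any claim that something is new, unique, unknown or untested is made for them only; others in the source may bear on it.

Measured compounds:
compound 1 `COc1c(C)ccc2c1CCC2c1ncc[nH]1` — > 10000 nM
compound 2 `COc1cccc2c1CCC2c1ncc[nH]1` — > 10000 nM
compound 3 `Clc1ccc2c(c1-c1ccn[nH]1)CCC2c1ncc[nH]1` — > 10000 nM

In a functional assay on CHO cells for agonist activity at Alpha-1D adrenergic receptor (Homo sapiens), read by FLIPR and calcium flux (on this read-out higher numbers stand for an effect only at larger amounts of compound and lower numbers for an effect already at smaller amounts), compound 1 gives > 10000 nM, which is a limit of the assay and not a number. Compound 2 likewise gives > 10000 nM, again a limit. Compound 3 gives > 10000 nM, also a limit. Compound 1 therefore stands nowhere that can be ranked: all three values sit at the same bound, (the limit of > 10000 nM in this assay, at which 3 of the 3 values shown sit), so no order among them can be read.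

Among the compounds with values here, the one step that links two measured compounds, a step that the two limits leave unreadable from compound 1 to compound 2, is unreadable for the same reason, both ends being limits.

The change to compound 4 `Cc1ccc2c(c1NS(C)(=O)=O)CCC2c1ncc[nH]1` is methanesulfonamido in place of methoxy on an aromatic carbon. Within the data shown here, no measured step bears directly on an exchange of this kind, and the one step that is recorded gives no size at all. There is thus no basis for expecting a step beyond the scatter in this assay in either direction; the expectation rests only on the bound where compound 1 sits.

Compound 4 is therefore expected to give about 8000 nM (estimated range 1000 nM to 30000 nM). The estimated step of an at least 1.2-fold lower number from compound 1 to compound 4 (0.09 log units; that floor lies within the scatter) is expected to be small.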

Compound 4, half-maximal effective concentration: > 10000 nM
Compound 4 gave a limit, no number; the forecaster's own chance of this, stated with the estimate: 60%; middle value at least 1.2-fold (0.09 log units) from the limit.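

In this assay compound 4 gives > 10000 nM, a limit and not a number. No step from compound 1 to compound 4 can be read, because both compounds sit at the same bound: the limit of > 10000 nM in this assay, at which 4 of the 4 values shown sit.

The compounds shown leave open whether methanesulfonamido in place of methoxy shifts the read-out in this assay in either direction.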